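Carboxy in place of bromo on an aromatic carbon

The compounds below may be only part of what the source reports. "The series", "measured", "known", "first", "only" and "open" are said of these compounds alone.

In a functional assay (mast cells) for inhibition, with Rattus norvegicus as the target (on this read-out higher numbers stand for an effect only at larger amounts of compound and lower numbers for an effect already at smaller amounts), compound 1 `CC1CC/C(=N\Nc2ccccc2F)c2ncc(C(=O)O)c(=O)n21` gives 1200 nM, and compound 3 `CC1CC/C(=N\Nc2ccc(Br)cc2)c2ncc(C(=O)O)c(=O)n21` gives 2000 nM. That gap is a 1.7-fold higher number from compound 1 to compound 3 (0.22 log units; within the scatter), so these two cannot be told apart. Compound 2 `CC1CC/C(=N\Nc2cccc(Cl)c2)c2ncc(C(=O)O)c(=O)n21` stands well apart at 311000 nM, the weakest of the three, and the step to compound 3 is large: a 160-fold lower number from compound 2 to compound 3 (2.19 log units; beyond the scatter). The step into it is similar, a 260-fold higher number from compound 1 to compound 2 (2.41 log units; beyond the scatter).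

Compound 4 `CC1CC/C(=N\Nc2ccc(C(=O)O)cc2)c2ncc(C(=O)O)c(=O)n21` differs from compound 3 by one change, carboxy in place of bromo on an aromatic carbon, para to a large group. Among the compounds with values here, no measured step makes this exchange, so the evidence is indirect. Within the data shown here, the three measured steps show only that swapping the group on this ring may change nothing beyond the scatter or may change a great deal. A moderate move to a higher number is therefore expected in this assay, an estimated 3.0-fold higher number from compound 3 to compound 4 (0.48 log units; beyond the scatter). The estimate for compound 4 is 6000 nM, with an expected range of 1000 nM to 100000 nM.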

Compound 4, half-maximal effective concentration: 1000000 nM
Estimate against measurement, compound 4: 170-fold (2.22 log units) below, outside the stated range (above it).
By their numbers in this assay, from the lowest: compounds 1 and 3 (each within the scatter of the next); then compound 2; then compound 4.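

In this assay, a 500-fold higher number from compound 3 to compound 4 (2.70 log units; beyond the scatter), so the group at this place on the ring, para to a large group, is far from indifferent. The earlier steps shown here each altered both the group and where it sat, whereas this one keeps the place fixed and changes only the group, which shows that the group alone can produce a large step. A substituent at this place therefore does not by itself keep the number low, as compound 3 alone might have suggested, and nothing measured here gives a reason for the size of this step.

The compounds shown leave open whether other groups at this place, such as a methyl ester, an amide or an amine, would stay close to compound 3 or move as far as compound 4. They also leave open how a carboxy group would behave elsewhere on the same ring.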